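From 4-fluorophenyl to 2-chlorophenyl in compound 4

The compounds below may be only part of what the source reports. "The series", "measured", "known", "first", "only" and "open" are said of these compounds alone.

In a functional assay on K562 cells (Homo sapiens) for antiproliferative activity, read by MTT assay, with a stated time of 48 h (on this read-out higher numbers stand for weaker inhibition and lower numbers for stronger inhibition), compound 1 `O=C(CCCCCn1cc(Nc2ncc(Cl)c(Nc3cccc(Cl)c3)n2)cn1)NO` gives 580 nM, compound 2 `O=C(CCCCCCn1cc(Nc2ncc(Cl)c(Nc3ccc(F)cc3)n2)cn1)NO` gives 500 nM, and compound 3 `O=C(CCCCCn1cc(Nc2ncc(Cl)c(Nc3ccc(F)cc3)n2)cn1)NO` gives 420 nM. Compound 2 therefore stands within the scatter of both other compounds. Compound 4 `O=C(CCCCCCn1cc(Nc2ncc(Cl)c(Nc3ccccc3Cl)n2)cn1)NO` differs from it in one place: 2-chlorophenyl in place of 4-fluorophenyl on a nitrogen on an aromatic ring. In words, 2-chlorophenyl sits in place of 4-fluorophenyl on a nitrogen on an aromatic ring. The nearest measured swap at that place is a 1.4-fold lower number from compound 1 to compound 3 (0.14 log units; within the scatter), and the step on the chain is a 1.2-fold lower number from compound 2 to compound 3 (0.08 log units; within the scatter). Among the compounds with values here, both stay within the scatter, but no measured compound carries 2-chlorophenyl, so some uncertainty remains. No step beyond the scatter is expected in this assay. The expected move is a 1.1-fold higher number from compound 2 to compound 4 (0.04 log units; within the scatter). For compound 4 the estimated value is 550 nM, within an expected range of 220 nM to 1400 nM.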

Compound 4, half-maximal inhibitory concentration: 860 nM
The estimate for compound 4 lay 1.6-fold (0.19 log units) below the measured number; the range from low to high includes it.
By their numbers in this assay, from the lowest: compounds 3, 2, 1 and 4 (each within the scatter of the next, the first and the last beyond it).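

On the nitrogen on an aromatic ring, 2-chlorophenyl in place of 4-fluorophenyl gives a 1.7-fold higher number from compound 2 to compound 4 (0.24 log units; within the scatter) in this assay. Within the data shown here, this is the first view of a 2-chlorophenyl group at this place, and the swap does not move the number beyond the scatter, so the two groups cannot be told apart here. Nothing available explains this result. Still open, on these data alone, is how an amine or a methoxy group on that phenyl ring would read out, and whether 2-chlorophenyl behaves the same on the chain of compound 3.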